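Serine benzyl ester in place of the isoleucine ester

This account rests on a few compounds, and the source may have more. Where it says the series, first, only, none or still open, it means among the compounds named here.

Of the compounds shown here, two have been measured in a functional assay on the whole organism (Tail, strain ICR) with Mus musculus as the target, in the tail flick test, with a stated time of 90 min, at a dose of 25 umol/kg by the oral route; a lower number here means a weaker effect, a higher number a stronger effect of the compound at the dose given. Compound 1, `N=C(N)NCCC[C@H](NC(=O)CN(c1ncnc2c1ncn2C1CCCCO1)C1CC1)C(=O)OCc1ccccc1`, gives 61.6% in this assay. Compound 2, `CC[C@H](C)[C@H](NC(=O)CN(c1nc(Cl)nc2[nH]cnc12)C1CC1)C(=O)OCc1ccccc1`, which carries a chlorine on a different core, gives 36.3% in this assay, the lower of the two numbers, a gap to compound 1 that is beyond the scatter. Compound 3, `O=C(CN(c1nc(Cl)nc2[nH]cnc12)C1CC1)N[C@@H](CO)C(=O)OCc1ccccc1`, has not yet been measured. It differs from compound 2 in one place: hydroxymethyl in place of sec-butyl on a saturated chain carbon bound to an amide-type nitrogen and a carbonyl carbon. Nothing else is changed, so the outcome cannot be read from any single-change pair already measured, and compound 1 shares neither the core nor the side chain of compound 2. He therefore expects the step in this assay from the sec-butyl to the hydroxymethyl to be small, with no clear direction and most likely not beyond the scatter, as a number 1.7 percentage points higher from compound 2 to compound 3 (within the scatter) states his expectation. For compound 3 he estimates a value of 38% in this assay, with a range from 12% to 62%.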

Compound 3, a percentage reported as activity, at one dose (the size of the read-out at that dose, not a potency): 34.5%
Beside the measured number, compound 3's estimate is 3.5 percentage points above it, and the stated range covers the measured number.
By their numbers in this assay, from the lowest: compounds 3 and 2 (each within the scatter of the next); then compound 1.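

In this assay, the change to hydroxymethyl in place of sec-butyl on a saturated chain carbon bound to an amide-type nitrogen and a carbonyl carbon gives a number 1.8 percentage points lower from compound 2 to compound 3 (within the scatter), the only single-change step among the compounds shown. It shows that, at this dose and on this core, the read-out does not separate the two groups, even though a group of 4 heavy atoms with no hydrogen-bond donor or acceptor gives way to one of 2 heavy atoms with 1 hydrogen-bond donor and 1 hydrogen-bond acceptor. Nothing given here explains why compound 2 and compound 3 read alike.

From the compounds shown here alone, whether this position tolerates change more generally remains open, since a single pair cannot show how an amine, a carboxylic acid or a longer chain in the same place would read in this assay. Compound 1 differs from compound 2 and compound 3 in more than one place, so its higher number cannot be assigned to its core, to its side chain or to any other single feature.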